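The source may hold more compounds than are shown below. What is called first, only, known or untested is meant among the compounds shown, and "the series" means these compounds.

Measured in a functional assay on HCT-116 cells (Homo sapiens) for antiproliferative activity, read by MTT assay, with a stated time of 48 h; on this read-out lower numbers stand for stronger inhibition and higher numbers for weaker inhibition:
- compound 1 `CCCCCCC[C@H](CCO)n1cnc2c(Cl)ncnc21`: 2670 nM
- compound 2 `CCCCCCCCC[C@H](CCO)n1cnc2c(Cl)ncnc21`: 450 nM
- compound 3 `CCCCCCCCC[C@@H](CCO)n1cnc2c(Cl)ncnc21`: 1050 nM

Compound 2, at 450 nM, holds the lowest number of the three. Compound 4 `CCCCCCCCC[C@H](CCOS(C)(=O)=O)n1cnc2c(Cl)ncnc21` departs from compound 2 by one change: methylsulfonyl in place of hydrogen on an oxygen on a saturated carbon. Neither measured step touches that oxygen. Ethyl in place of hydrogen on a saturated chain carbon gave a 5.9-fold lower number from compound 1 to compound 2 (0.77 log units; beyond the scatter). Inverting the stereocentre gave a 2.3-fold higher number from compound 2 to compound 3 (0.37 log units; beyond the scatter), a shift seen because of the fact that compounds 2 and 3 differ only in the configuration as drawn. Both steps are modest and only indicate the scale of change in this small set. A step of similar size is therefore expected in this assay, tentatively towards a higher number. The expected step is a 1.8-fold higher number from compound 2 to compound 4 (0.25 log units; within the scatter). For compound 4 the estimated value is 800 nM, with an expected range of 200 nM to 3000 nM.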

Compound 4, half-maximal inhibitory concentration: 9480 nM
Compound 4: middle estimate off by 12-fold (1.07 log units), on the low side; measured number outside the range, above it.
By their numbers in this assay, from the lowest: compound 2; then compound 3; then compound 1; then compound 4.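

In this assay, the oxygen of the 2-hydroxyethyl group proves the most sensitive place touched in this set: going from 2-hydroxyethyl to 2-((methylsulfonyl)oxy)ethyl gave a 21-fold higher number from compound 2 to compound 4 (1.32 log units; beyond the scatter). Going by these compounds alone, this step is large, whereas the earlier steps on the chain and at the stereocentre were modest. Nothing given here accounts for it. As far as these compounds go, it remains open whether any replacement of the hydrogen on that oxygen has this effect or whether it is specific to methylsulfonyl. A methyl ether, an acetate ester or an amine at this place would help separate the two.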